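Acyl group variation: step from compound 3 to compound 4

This account rests on a few compounds, and the source may have more. Where it says the series, first, only, none or still open, it means among the compounds named here.

Measured in an assay on LtK cells with ATP-sensitive inward rectifier potassium channel 11 (Homo sapiens) as the target; a higher number here means that more compound is needed for the effect, a lower number that less compound is needed:
compound 1 `CC(=O)Nc1c(C(O)(C(F)(F)F)C(F)(F)F)ccc2ccccc12` gives 18 nM.
compound 2 `CCCC(C)C(=O)Nc1c(C(O)(C(F)(F)F)C(F)(F)F)ccc2ccccc12` gives only a limit, > 10000 nM.
compound 3 `Cc1ccccc1C(=O)Nc1c(C(O)(C(F)(F)F)C(F)(F)F)ccc2ccccc12` gives 5550 nM.

Of the two numbers, compound 3 holds the higher one. The step of a 310-fold higher number from compound 1 to compound 3 (2.49 log units; beyond the scatter) is large, as is an at least 550-fold higher number from compound 1 to compound 2 (2.74 log units; beyond the scatter), which ends at the limit (the limit of > 10000 nM in this assay, at which 1 of the 3 values shown sits). Between the two larger acyl groups, an at least 1.8-fold lower number from compound 2 to compound 3 (0.25 log units; that floor lies within the scatter) lies within the scatter.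

Compound 4 `O=C(Nc1c(C(O)(C(F)(F)F)C(F)(F)F)ccc2ccccc12)c1cccc(C(F)(F)F)c1` differs from compound 3 by 3-(trifluoromethyl)phenyl in place of 2-methylphenyl on a carbonyl carbon. Going by the values given here, no measured step exchanges one aryl group for another; the only large steps start from the methyl of compound 1. Compound 4 is therefore expected to stay close to compound 3, with an expected step of a 1.1-fold higher number from compound 3 to compound 4 (0.03 log units; within the scatter) within the scatter. The estimate for compound 4 in this assay is 6000 nM, range 1500 nM to 30000 nM.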

Compound 4, half-maximal effective concentration: 84 nM
The estimate for compound 4 lay 71-fold (1.85 log units) above the measured number; measured number outside the range, below it.
By their numbers in this assay, from the lowest: compound 1; then compound 4; then compound 3. At a limit, above all of these: compound 2.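

In this assay, the aryl group on the carbonyl carbon matters strongly, as a 66-fold lower number from compound 3 to compound 4 (1.82 log units; beyond the scatter) shows for 3-(trifluoromethyl)phenyl in place of 2-methylphenyl. Replacing methyl with an aryl group need not cost much: a 4.7-fold higher number from compound 1 to compound 4 (0.67 log units; beyond the scatter) is a modest step, so the large losses seen with compound 2 and compound 3 do not hold for every group larger than methyl. The step of an at least 110-fold lower number from compound 2 to compound 4 (2.07 log units; beyond the scatter) starts from a limit: the limit of > 10000 nM in this assay, at which 1 of the 4 values shown sits.

The compounds shown do not separate the identity of the ring substituent from its place on the ring. Where a plain phenyl, a pyridyl or an ethyl on the carbonyl carbon would fall remains open.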